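The compounds below may be only part of what the source reports. "The series", "measured", "known", "first", "only" and "open" are said of these compounds alone.

Within the data shown here, compound 2 `O=c1n(Cc2nc3cc(F)ccn3c2CCCCO)c2cnccc2n1C1CC1` is one of two compounds measured in an ADME assay on HEp-2 cells (Homo sapiens) for cytotoxicity, read by CCK-8 assay, with a stated time of 6 days; a lower number here means that less compound is tolerated, a higher number that more compound is tolerated. In this assay compound 2 gives > 100000 nM, which is a limit of the assay and not a number. Compound 1 `O=c1n(Cc2nc3ccc(Cl)cn3c2CCCCO)c2cnccc2n1C1CC1` likewise gives > 100000 nM, again only a limit. Both sit at the limit of > 100000 nM in this assay, at which 2 of the 2 values shown sit, so nothing separates them. Compound 3 `O=c1n(Cc2nc3ccccn3c2CCCCO)c2cnccc2n1C1CC1` differs from compound 2 by hydrogen in place of fluoro on an aromatic carbon. No step beyond the scatter is expected from compound 2 to compound 3 in this assay. The expected step is a number no higher from compound 2 to compound 3 (the limit leaves the size open). Compound 3 is estimated at 100000 nM, between 50000 nM and 200000 nM, most likely reported once more only as a limit.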

Compound 3, half-maximal cytotoxic concentration: > 100000 nM
Compound 3 ended at the assay's limit (the forecaster's own chance of this, stated with the estimate: 85%); the middle value sits exactly at the limit.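

Among these compounds, compound 3 sits at the same limit as compound 1 and compound 2, so no step from either of them to compound 3 can be read: the limit of > 100000 nM in this assay, at which 3 of the 3 values shown sit.

In this assay the compounds shown leave open at what concentration, if any, each one becomes toxic to the cells.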